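The source may report more compounds than this note shows. Statements on the series, on what has been measured and on what is new or still open speak of the compounds shown alone.

Values in a functional assay on KB cells (Homo sapiens) for antiproliferative activity, read by MTT assay (a higher number here means a weaker inhibitor, a lower number a stronger inhibitor), for the measured compounds:

compound 1 `COc1cc(OC)c(-c2nc(N3CCN(C)CC3)nc3ccccc23)c(OC)c1`: compound 1 gives 50 ug/mL
compound 2 `COc1cc(OC)c(-c2nc(N3CCNCC3)nc3ccccc23)c(OC)c1`: compound 2 gives 50 ug/mL
compound 3 `Cn1cc(-c2nc(N3CCNCC3)nc3ccccc23)c2ccccc21`: compound 3 gives 50 ug/mL

Compounds 1 and 2 share one core; compound 3 carries a different one. The difference between the two cores is not broken down here. Compound 3 stands level with compounds 1 and 2 in this assay within the scatter, and the three values show no order among them.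

One structural change occurs twice among these compounds. From compound 2 to compound 1 it is methyl in place of hydrogen on an amine nitrogen in a ring, and the step in this assay is no change at the digits printed from compound 2 to compound 1 (within the scatter). The unmeasured compound 4 `CN1CCN(c2nc(-c3cn(C)c4ccccc34)c3ccccc3n2)CC1` carries the same change on the core of compound 3: methyl in place of hydrogen on an amine nitrogen in a ring. The place of the change is the same word for word in both pairs, so it is the same change, made on a different core.

Nothing beyond this single measured pair supports any expectation for compound 4, and the pair shows no movement. The step from compound 3 to compound 4 in this assay is therefore expected to be no change at the digits printed from compound 3 to compound 4 (within the scatter) because no change at the digits printed from compound 2 to compound 1 (within the scatter) shows no change on the other core. Compound 4 is estimated at 50 ug/mL in this assay, with the expected range from 25 ug/mL to 100 ug/mL. Since every measured value here sits at the same figure, a reported limit rather than a number is a real possibility for compound 4.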

Compound 4, half-maximal inhibitory concentration: 50 ug/mL
Compound 4: middle estimate and measured number agree at the digits printed; low and high end bracket the measured number.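

In this assay the new step reads no change at the digits printed from compound 3 to compound 4 (within the scatter). Set beside the earlier step, methyl in place of hydrogen on an amine nitrogen in a ring carries from one core to the other without a difference between the two steps: the same change on two cores in this assay, no change at the digits printed (within the scatter) from compound 2 to compound 1 and no change at the digits printed (within the scatter) from compound 3 to compound 4, 1.0-fold (0.00 log units) apart, within the scatter of two such steps

Among the compounds shown here, this shows only that the change leaves the reading in place on both cores. All four compounds share one figure, with compound 4 at 50 ug/mL, so the two flat steps do not show how the change would behave on a compound reading at another figure, nor do they show that the two cores are alike in any other respect.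

The compounds shown carry only hydrogen or methyl on that ring nitrogen, so a longer chain, a benzyl group or an acetyl group there remains open, as does replacing the piperazin-1-yl group with another amine such as morpholine. On these data alone, whether any such change moves a compound of this series away from the shared figure in this assay also remains open.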